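This account rests on a few compounds, and the source may have more. Where it says the series, first, only, none or still open, it means among the compounds named here.

In a functional assay on HepG2 cells (Homo sapiens) for antiproliferative activity, read by MTT assay, with a stated time of 48 h (on this read-out lower numbers stand for stronger inhibition and higher numbers for weaker inhibition), compound 3 `COc1ccc(CN(C(=O)Cn2cc(CSc3nncs3)nn2)c2cc(OC)c(OC)c(OC)c2)cc1` gives 38600 nM, compound 1 `COc1ccc(CN(C(=O)Cn2cc(CSC3=NCCS3)nn2)c2cc(OC)c(OC)c(OC)c2)cc1` gives 25000 nM and compound 2 `COc1ccc(CN(C(=O)Cn2cc(CSc3nnc(-c4ccccc4)c(-c4ccccc4)n3)nn2)c2cc(OC)c(OC)c(OC)c2)cc1` gives 21800 nM. These three values lie within the scatter of one another, so compound 3 is not separated from either of the other two. Compound 4 `COc1ccc(CN(C(=O)Cn2cc(CNS(=O)(=O)c3ccc(Br)cc3)nn2)c2cc(OC)c(OC)c(OC)c2)cc1` differs from compound 3 as follows: ((4-bromophenyl)sulfonyl)amino in place of (1,3,4-thiadiazol-2-yl)sulfanyl on a saturated chain carbon bound to an aromatic carbon. ((4-Bromophenyl)sulfonyl)amino thus stands in place of (1,3,4-thiadiazol-2-yl)sulfanyl on a saturated chain carbon bound to an aromatic carbon. Among the measured compounds shown here, the only measured step offers indirect guidance: a 1.5-fold higher number from compound 1 to compound 3 (0.19 log units; within the scatter), a change of the group on a sulfur that stays within the scatter. For the measured compounds named here, no measured compound carries the entering group, so the data give no direct size for this change. No step beyond the scatter is expected in this assay, and no direction is favoured, though the uncertainty is wide. The expected step is a 1.5-fold lower number from compound 3 to compound 4 (0.19 log units; within the scatter). The estimate for compound 4 is 25000 nM, with an expected range of 8000 nM to 60000 nM.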

Compound 4, half-maximal inhibitory concentration: 7370 nM
For compound 4 the middle estimate is 3.4-fold (0.53 log units) above the measured one; measured number outside the range, below it.
By their numbers in this assay, from the lowest: compound 4; then compounds 2, 1 and 3 (each within the scatter of the next).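

In this assay, the saturated chain carbon bound to an aromatic carbon responds to a change of group beyond the scatter, whereas compounds 1, 2 and 3 stay within the scatter of one another. Placing ((4-bromophenyl)sulfonyl)amino there gives a 5.2-fold lower number from compound 3 to compound 4 (0.72 log units; beyond the scatter) when it replaces (1,3,4-thiadiazol-2-yl)sulfanyl and a 3.4-fold lower number from compound 1 to compound 4 (0.53 log units; beyond the scatter) when it replaces the non-aromatic group of compound 1, so both steps are modest and point the same way. No measured evidence accounts for this shift.

The entering group differs from those it replaces in both its linking atoms and its ring, so these two contributions cannot be separated. A phenylsulfonylamino group without the bromine, or a carboxamide link carrying the same 4-bromophenyl ring, would be needed to tell them apart.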